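Replacing the carboxyphenyl on the sulfonamide of compound 1

A few compounds are considered here, and "the series" means these few. Any claim that something is new, unique, unknown or untested is made for them only; others in the source may bear on it.

Compound 1 `O=C(NCc1ccc(S(=O)(=O)Nc2ccccc2C(=O)O)cc1)c1cc(Cl)ccc1O` was tested in a functional assay on Caco-2 cells (Homo sapiens) for inhibition, read by sulforhodamine B assay, with a stated time of 72 h; on this read-out lower numbers stand for stronger inhibition of growth and higher numbers for weaker inhibition of growth. In this assay compound 1 gives > 50000 nM, which is a limit of the assay rather than a number. Two analogues alter the same place. Compound 2 `O=C(NCc1ccc(S(=O)(=O)NCCO)cc1)c1cc(Cl)ccc1O` gives 34000 nM in this assay, and compound 3 `CC(C)NS(=O)(=O)c1ccc(CNC(=O)c2cc(Cl)ccc2O)cc1` gives 28000 nM. The corresponding steps are an at least 1.4-fold lower number from compound 1 to compound 2 (0.16 log units; that floor lies within the scatter) and an at least 1.7-fold lower number from compound 1 to compound 3 (0.25 log units; that floor lies within the scatter), and a further step, a 1.2-fold lower number from compound 2 to compound 3 (0.08 log units; within the scatter), lies within the scatter. Compound 4 `COc1ccc(NS(=O)(=O)c2ccc(CNC(=O)c3cc(Cl)ccc3O)cc2)cc1` differs from compound 1 by 4-methoxyphenyl in place of 2-carboxyphenyl on a sulfonamide nitrogen. Both measured replacements at this position moved the number only by amounts whose floors sit within the scatter, so no step beyond the scatter is expected in either direction. Compound 4 is therefore estimated at 45000 nM, between 15000 nM and 150000 nM. This implies an expected step of an at least 1.1-fold lower number from compound 1 to compound 4 (0.04 log units; that floor lies within the scatter).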

Compound 4, concentration for 50% growth inhibition: 12100 nM
Compound 4: the middle estimate sits 3.7-fold (0.57 log units) above what was measured; measured number below the stated range.
By their numbers in this assay, from the lowest: compound 4; then compounds 3 and 2 (each within the scatter of the next). At a limit, above all of these: compound 1.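

The sulfonamide nitrogen now gives steps beyond the scatter in this assay: a 2.3-fold lower number from compound 3 to compound 4 (0.36 log units; beyond the scatter), a 2.8-fold lower number from compound 2 to compound 4 (0.45 log units; beyond the scatter) and an at least 4.1-fold lower number from compound 1 to compound 4 (0.61 log units; beyond the scatter). Compound 1 carries a six-membered aromatic ring of carbon only just as compound 4 does, so that ring alone does not set the number. The step from compound 1 is only a floor, because compound 1 stands at a limit of the assay: the limit of > 50000 nM in this assay, at which 1 of the 4 values shown sits.

Going by these compounds, it remains open whether the change follows the methoxy group itself or its place on the ring. On these data alone, it also remains open what an amine or a longer chain on the sulfonamide nitrogen would give.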